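From 3-methylphenyl to 4-fluorophenyl on the shared core

The compounds below may be only part of what the source reports. "The series", "measured", "known", "first", "only" and "open" are said of these compounds alone.

Measured in a functional assay on DU-145 cells (Homo sapiens) for cytotoxicity, read by sulforhodamine B assay, with a stated time of 48 h; on this read-out higher numbers stand for weaker inhibition and lower numbers for stronger inhibition:
- compound 1 `C[C@H]1CC[C@@H]2[C@@H](OC(=O)[C@]23CC(c2ccccc2)=NO3)[C@]2(C)C(=O)C=C[C@@]12O`: 39800 nM
- compound 2 `C[C@H]1CC[C@@H]2[C@@H](OC(=O)[C@]23CC(c2ccccc2[N+](=O)[O-])=NO3)[C@]2(C)C(=O)C=C[C@@]12O`: 34000 nM
- compound 3 `Cc1cccc(C2=NO[C@]3(C2)C(=O)O[C@@H]2[C@H]3CC[C@H](C)[C@]3(O)C=CC(=O)[C@@]23C)c1`: 28000 nM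

Compound 3 does not stand apart from the other two compounds in this assay. Both steps that reach it, a 1.4-fold lower number from compound 1 to compound 3 (0.15 log units; within the scatter) and a 1.2-fold lower number from compound 2 to compound 3 (0.08 log units; within the scatter), stay within the scatter.

The compound still to be measured is compound 4 `C[C@H]1CC[C@@H]2[C@@H](OC(=O)[C@]23CC(c2ccc(F)cc2)=NO3)[C@]2(C)C(=O)C=C[C@@]12O`. It carries 4-fluorophenyl in place of 3-methylphenyl on a carbon with a double bond to nitrogen.

For the measured compounds named here, three measured steps bear on this change, all of them on the same aromatic group. Adding methyl gave a 1.4-fold lower number from compound 1 to compound 3 (0.15 log units; within the scatter), adding nitro gave a 1.2-fold lower number from compound 1 to compound 2 (0.07 log units; within the scatter), and exchanging the two substituted phenyl groups gave a 1.2-fold lower number from compound 2 to compound 3 (0.08 log units; within the scatter). Going by the values given here, none of the measured compounds carries fluorine, so the expectation rests on these three steps alone. With all three inside the scatter, no step beyond the scatter is expected, and the estimate is a 1.2-fold higher number from compound 3 to compound 4 (0.07 log units; within the scatter).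

Compound 4 is expected at 33000 nM, with an estimated range from 16000 nM to 65000 nM.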

Compound 4, half-maximal inhibitory concentration: 13000 nM
For compound 4 the middle estimate is 2.5-fold (0.40 log units) above the measured one; measured number outside the range, below it.
By their numbers in this assay, from the lowest: compound 4; then compounds 3, 2 and 1 (each within the scatter of the next).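

In this assay, for the compounds shown here, 4-fluorophenyl is the first group on this carbon with a double bond to nitrogen to move the number beyond the scatter, with a 2.2-fold lower number from compound 3 to compound 4 (0.33 log units; beyond the scatter), a 2.6-fold lower number from compound 2 to compound 4 (0.42 log units; beyond the scatter) and a 3.1-fold lower number from compound 1 to compound 4 (0.49 log units; beyond the scatter), whereas phenyl, 2-nitrophenyl and 3-methylphenyl stayed within the scatter of one another. The position therefore does respond to the aromatic group it carries, and compound 4 has the lowest number of the four, though the steps are modest. Nothing available explains this difference.

The compounds shown leave open whether the gain belongs to fluorine itself or to a substituent at the place it holds in 4-fluorophenyl. A comparison of 4-fluorophenyl with 3-fluorophenyl, 4-methylphenyl and 4-chlorophenyl on the shared core would separate these two readings.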